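Shortening the chain on a fluorophenylsulfonamide series

The compounds below may be only part of what the source reports. "The series", "measured", "known", "first", "only" and "open" are said of these compounds alone.

Compound 1 `O=S(=O)(NCCCNc1nccc(-c2c(-c3cccc(F)c3)nc3sccn23)n1)c1cccc(F)c1` gives 13700 nM in a functional assay on A-375 cells (Homo sapiens) for cytotoxicity, read by MTT assay; a lower number here means a stronger inhibitor, a higher number a weaker inhibitor.
Compound 2 `O=S(=O)(NCCCNc1nccc(-c2c(-c3cccc(F)c3)nc3sccn23)n1)c1ccc(F)cc1` gives 14500 nM in this assay.
Compound 3 `O=S(=O)(NCCNc1nccc(-c2c(-c3cccc(F)c3)nc3sccn23)n1)c1ccc(F)cc1` gives 9450 nM in this assay.

Compound 1 sits close to compound 2, with a 1.1-fold higher number from compound 1 to compound 2 (0.02 log units; within the scatter), and only a little further from compound 3, with a 1.4-fold lower number from compound 1 to compound 3 (0.16 log units; within the scatter); none of the three differs from another beyond the scatter. Compound 4 `O=S(=O)(NCCNc1nccc(-c2c(-c3cccc(F)c3)nc3sccn23)n1)c1cccc(F)c1` is not yet measured. It differs from compound 1 in one place: ((3-fluorophenyl)sulfonyl)amino in place of (((3-fluorophenyl)sulfonyl)amino)methyl on a saturated chain carbon, two bonds along the chain from a nitrogen on an aromatic ring. Going by the values given here, the closest precedent is the same shortening of the chain in the 4-fluorophenyl pair, a 1.5-fold lower number from compound 2 to compound 3 (0.19 log units; within the scatter), which stayed within the scatter. Compound 4 is therefore expected to show at most a small step, a 1.4-fold lower number from compound 1 to compound 4 (0.15 log units; within the scatter), in this assay. Compound 4 is estimated at 9800 nM, in the range 4500 nM to 21000 nM.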

Compound 4, half-maximal inhibitory concentration: 14900 nM
For compound 4 the middle estimate is 1.5-fold (0.18 log units) below the measured one; the measured number falls inside the stated range.
By their numbers in this assay, from the lowest: compounds 3, 1, 2 and 4 (each within the scatter of the next).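

In this assay, shortening the chain with the 3-fluorophenyl group in place also stays within the scatter, with a 1.1-fold higher number from compound 1 to compound 4 (0.04 log units; within the scatter). Exchanging 4-fluorophenyl for 3-fluorophenyl on the sulfonyl sulfur of the shorter chain gives a 1.6-fold higher number from compound 3 to compound 4 (0.20 log units; within the scatter), and the pair differing in the whole sulfonylamino chain gives a 1.0-fold higher number from compound 2 to compound 4 (0.01 log units; within the scatter). The fluorine exchange can now be read on both chain lengths, and the two steps agree within the scatter: the same change on two cores in this assay, a 1.1-fold higher number (0.02 log units; within the scatter) from compound 1 to compound 2 and a 1.6-fold lower number (0.20 log units; within the scatter) from compound 4 to compound 3, 1.7-fold (0.22 log units) apart, within the scatter of two such steps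

The compounds shown leave open whether any change here would take the number beyond the scatter. On these data alone, what a longer chain, or an amine in place of the fluorine, would give in this assay remains open.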